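The source may hold more compounds than are shown below. What is called first, only, known or untested is meant among the compounds shown, and "the series" means these compounds.

Compound 1 `CC(=O)N1N=C(c2ccc(F)cc2)CC1c1cn(-c2ccccc2)nc1-c1ccc(F)cc1`: 43%
Compound 2 `CC(=O)N1N=C(c2ccc(F)cc2)CC1c1cn(-c2ccccc2)nc1-c1ccc(Br)cc1`: 71%
Compound 3 `Fc1ccc(C2=NN(c3ccccc3)C(c3cn(-c4ccccc4)nc3-c3ccc(F)cc3)C2)cc1`: 41%

All three were tested in a functional assay on the whole organism (Tail) with Rattus norvegicus as the target, in the tail flick test, with a stated time of 60 min, at a dose of 25 mg/kg by the oral route; on this read-out lower numbers stand for less inhibition and higher numbers for more inhibition at the one dose given (going by the name of the read-out). Compound 3 carries the lowest of the three numbers, although compound 1 lies within the scatter of it, the step being a number 2 percentage points lower from compound 1 to compound 3 (within the scatter). Compound 2 stands clearly higher, the step from compound 1 being a number 28 percentage points higher from compound 1 to compound 2 (beyond the scatter).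

Compound 4 `Cc1ccc(-c2nn(-c3ccccc3)cc2C2CC(c3ccc(F)cc3)=NN2c2ccccc2)cc1` is not yet measured. It differs from compound 3 in one place: methyl in place of fluoro on an aromatic carbon.

Among the measured compounds shown here, one measured step bears on this change. In the move from compound 1 to compound 2, bromo replaced fluoro on an aromatic carbon of the same ring, and the number rose by a number 28 percentage points higher from compound 1 to compound 2 (beyond the scatter), a modest gain beyond the scatter. The step of a number 2 percentage points lower from compound 1 to compound 3 (within the scatter) concerns a different part of the molecule and offers no guide here. Replacing fluoro by methyl on that ring is therefore expected to raise the number somewhat, though a single related step leaves the size uncertain. Compound 4 is expected to give 52%, in the range 32% to 72%. This estimate means an expected step of a number 11 percentage points higher from compound 3 to compound 4 (beyond the scatter).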

Compound 4, a percentage reported as inhibition, in the whole organism at one dose (the size of the read-out at that dose, not a potency): 110%
Estimate against measurement, compound 4: 58 percentage points below; the measured number lies above the stated range.
By their numbers in this assay, from the lowest: compounds 3 and 1 (each within the scatter of the next); then compound 2; then compound 4.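

Going from 4-fluorophenyl to 4-methylphenyl exchanges one heavy atom for one heavy atom, yet it gives the largest step seen so far in this assay (a number 69 percentage points higher from compound 3 to compound 4 (beyond the scatter)). Bromo in place of fluoro had also raised the number (a number 28 percentage points higher from compound 1 to compound 2 (beyond the scatter)), so both listed replacements of fluoro on this aromatic carbon now point upward, one with acetyl and one with phenyl on the amine nitrogen in the ring, and neither listed pair goes against this. Nothing measured here explains why the number rises.

The compounds shown leave open how a group such as methoxy, an amine or a carboxylic acid would read in this same place. They also leave open whether methyl would give a step of similar size with acetyl on the ring nitrogen.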